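Trading Two Methyl Groups for Fluorine on the Sulfonyl Arm

The source may hold more compounds than are shown below. What is called first, only, known or untested is meant among the compounds shown, and "the series" means these compounds.

Measured compounds:
- Compound 1 `Cc1ccc(S(=O)(=O)c2cnc3cc(F)ccc3c2-c2ccc(F)cc2)cc1C` gives 9.25 mL/min in an ADME assay on microsomes from liver (Homo sapiens) for metabolic stability, tested at 2.5 uM; on this read-out lower numbers stand for slow clearance and higher numbers for fast clearance.
- Compound 2 `COc1cccc(-c2c(S(=O)(=O)c3ccc(C)c(C)c3)cnc3cc(F)ccc23)c1` gives 8.78 mL/min in this assay.

Going by the values given here, only two compounds have numbers so far. Compound 1 has the highest of the two numbers, and its nearest neighbour is compound 2, with the step of a 1.1-fold lower number from compound 1 to compound 2 (0.02 log units; within the scatter). That step swaps the aryl group on the aromatic carbon of the shared core; it leaves the two compounds within the scatter of each other, so no order between them can be claimed.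

Compound 3 `O=S(=O)(c1ccc(F)cc1)c1cnc2cc(F)ccc2c1-c1ccc(F)cc1` has not yet been measured in this assay. It differs from compound 1 at the other arm of the molecule: 4-fluorophenyl in place of 3,4-dimethylphenyl on a sulfonyl sulfur. Among the compounds with values here, no measured step touches the group on the sulfonyl sulfur, so the one step in hand does not bear directly on this change. Within the data shown here, the only guide is that the sole aryl swap seen so far, from compound 1 to compound 2, stayed within the scatter. On that basis compound 3 is expected to land near compound 1, with the step of a 1.2-fold lower number from compound 1 to compound 3 (0.06 log units; within the scatter) not clearly beyond the scatter, and an estimate for compound 3 of 8 mL/min, between 4 mL/min and 16 mL/min.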

Compound 3, intrinsic clearance in a liver preparation (reported as CLH), per the amount of preparation that the assay uses: 1.34 mL/min
Beside the measured number, compound 3's estimate is 6.0-fold (0.78 log units) above it, outside the stated range (below it).
By their numbers in this assay, from the lowest: compound 3; then compounds 2 and 1 (each within the scatter of the next).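

Of the two arms of the molecule, the group on the sulfonyl sulfur is the one that has moved the number in this assay beyond the scatter. Putting 4-fluorophenyl in place of 3,4-dimethylphenyl there gives a 6.9-fold lower number from compound 1 to compound 3 (0.84 log units; beyond the scatter), whereas the aryl swap at the other arm, a 1.1-fold lower number from compound 1 to compound 2 (0.02 log units; within the scatter), did not separate its two compounds. The change therefore shifts the read-out towards slow clearance, but nothing at hand accounts for the shift.

This one swap removes the methyl groups and brings in the fluorine together, so the compounds shown cannot tell which of the two matters, and a plain phenyl or a 4-methylphenyl on the sulfonyl sulfur would pull them apart. On these data alone, it also stays open whether the same swap holds when 3-methoxyphenyl sits at the other arm, as in compound 2, and how a group of a different kind on the sulfonyl arm, such as an amine or a carboxylic acid, would read in this assay.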